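From Fluoro to Methoxy on an Inactive Compound

The source may report more compounds than this note shows. Statements on the series, on what has been measured and on what is new or still open speak of the compounds shown alone.

The three compounds share one core, and two have been tested in a functional assay on HL-60 cells (Homo sapiens) for inhibition, read by CCK-8 assay, with a stated time of 48 h, tested at 20 uM; a lower number here means less inhibition of growth, a higher number more inhibition of growth at the concentration tested. Compound 1 (`N#C/C(=C\c1cccc(OS(=O)(=O)c2cccs2)c1)C(=O)Nc1nnc(-c2cccs2)s1`) gives 30%. Compound 2 (`N#C/C(=C\c1cccc(NS(=O)(=O)c2ccc(F)cc2)c1)C(=O)Nc1nnc(-c2cccs2)s1`) is recorded as "not active" (no number reported), so it has no single number and stands only as a qualitative result. This leaves a weak reference point for what follows.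

Compound 3 (`COc1ccc(S(=O)(=O)Nc2cccc(/C=C(\C#N)C(=O)Nc3nnc(-c4cccs4)s3)c2)cc1`) has not yet been measured. It departs from compound 2 at one place, with methoxy in place of fluoro on an aromatic carbon, para to a large group: methoxy in place of fluoro on an aromatic carbon. The 4-fluorophenyl thus becomes 4-methoxyphenyl.

No measured pair of these compounds differs at one place only, so the data offer no direct precedent for the size of this change. In this assay, no step beyond the usual scatter is expected, and any small movement is expected to be upward. The expectation stays near the low end, as compound 2 reads "not active" (no number reported). A second outcome without a number is also plausible.

The estimate for compound 3 is 12%, with an expected range of 0% to 32%.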

Compound 3, percent growth inhibition at one concentration: 77%
The estimate for compound 3 lay 65 percentage points below the measured number; measured number outside the range, above it.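

The step from compound 2 to compound 3 cannot be read: in this assay compound 2 stands as "not active" (no number reported), while compound 3 gives 77%. The compounds shown leave open how large a change 4-methoxyphenyl in place of 4-fluorophenyl makes on a numerical scale. Nothing shown bears on the reason for this result.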